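The source may hold more compounds than are shown below. What is called first, only, known or untested is meant among the compounds shown, and "the series" means these compounds.

Compound 1 `O=C(CCCc1cn(Cc2ccc(Br)cc2)c2ccccc12)NC1CCCCCC1`: "not determined" (no result reported)
Compound 2 `Cc1ccc(S(=O)(=O)n2cc(CCCC(=O)NC3CCCCCC3)c3ccccc32)cc1`: > 250000 nM
Compound 3 `CC(C)(C)c1ccc(S(=O)(=O)n2cc(CCCC(=O)NC3CCCCCC3)c3ccccc32)cc1`: > 250000 nM

In an ADME assay on Vero cells (Chlorocebus sabaeus) for cytotoxicity, read by fluorescence and resazurin assay, with a stated time of 3 days (on this read-out lower numbers stand for higher toxicity in this test and higher numbers for lower toxicity in this test), compound 2 gives > 250000 nM, which is a limit of the assay and not a number. Compound 3 gives > 250000 nM, which is also a limit. Compound 1 has no result to compare. The measured picture is therefore thin, and it comes down to the limit of > 250000 nM in this assay, at which 2 of the 3 values shown sit.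

Compound 4 `Cc1cc(S(=O)(=O)n2cc(CCCC(=O)NC3CCCCCC3)c3ccccc32)c(C)cc1Cl` has not yet been measured. It differs from compound 2 by one change, (4-chloro-2,5-dimethylphenyl in place of 4-methylphenyl on a sulfonyl sulfur), which puts 4-chloro-2,5-dimethylphenyl in place of 4-methylphenyl on a sulfonyl sulfur. The rest of the molecule stays the same.

Going by the values given here, the one measured step that bears on this, a step that the two limits leave unreadable from compound 2 to compound 3, puts tert-butyl in place of methyl on an aromatic carbon and gives no size to carry over, so no step beyond the usual scatter is expected in this assay. The likeliest report is another limit rather than a number. The expected outcome is a number no higher from compound 2 to compound 4 (the limit leaves the size open). The estimate for compound 4 is 250000 nM, with an expected range from 100000 nM to 500000 nM.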

Compound 4, half-maximal cytotoxic concentration: > 250000 nM
Compound 4: only a limit was reported (the forecaster's own chance of this, stated with the estimate: 75%); the middle value sits exactly at the limit.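

Compound 4 gives a limit of the assay and not a number, as do compound 2 and compound 3, so no step among these three compounds can be read in this assay. The compounds shown leave open how far past that limit each one lies, and whether the different groups on the sulfonyl sulfur matter for toxicity in this test.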